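Hydroxyphenyl pyridines: pyridin-2-yl replacing phenyl

The source may hold more compounds than are shown below. What is called first, only, known or untested is meant among the compounds shown, and "the series" means these compounds.

compound 1 `Oc1cccc(-c2cc(-c3ccc(Cl)cc3)nc(-c3ccccn3)c2)c1`: 8090 nM
compound 2 `Oc1ccc(-c2cc(-c3ccccc3)nc(-c3ccc(Cl)cc3)c2)cc1`: 7270 nM

In a functional assay on DU-145 cells (Homo sapiens) for cytotoxicity, read by CCK-8 assay and cell counting, with a stated time of 2 days (on this read-out lower numbers stand for stronger inhibition and higher numbers for weaker inhibition), compound 1 gives 8090 nM and compound 2 gives 7270 nM; the two numbers lie within the scatter of each other, so neither stands apart. Compound 3 `Oc1ccc(-c2cc(-c3ccc(Cl)cc3)nc(-c3ccccn3)c2)cc1` differs from compound 2 by pyridin-2-yl in place of phenyl on an aromatic carbon. Among the measured compounds shown here, no measured pair in this set isolates that change, and compound 1, which also carries pyridin-2-yl, sits within the scatter of compound 2. Compound 3 is therefore expected to stay near compound 2, with a step of a 1.0-fold lower number from compound 2 to compound 3 (0.02 log units; within the scatter) that is not beyond the scatter. The estimate for compound 3 is 7000 nM, within 3000 nM to 16000 nM.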

Compound 3, half-maximal inhibitory concentration: 22500 nM
The estimate for compound 3 lay 3.2-fold (0.51 log units) below the measured number, and the stated range ends below it.
By their numbers in this assay, from the lowest: compounds 2 and 1 (each within the scatter of the next); then compound 3.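

At the place next to the ring nitrogen, pyridin-2-yl in place of phenyl weakens inhibition in this assay, with a 3.1-fold higher number from compound 2 to compound 3 (0.49 log units; beyond the scatter) as the step. With pyridin-2-yl held, the position of the hydroxyl also matters: 4-hydroxyphenyl in place of 3-hydroxyphenyl gives a 2.8-fold higher number from compound 1 to compound 3 (0.44 log units; beyond the scatter) as the step, so the effect of the ring nitrogen may depend on the hydroxyl position. Nothing available accounts for either step. Open, from the compounds shown here alone, is whether a pyridin-3-yl group or an aminomethyl group at this place would behave like pyridin-2-yl, and whether a methoxy group could replace the hydroxyl.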